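The source may hold more compounds than are shown below. What is called first, only, known or untested is meant among the compounds shown, and "the series" means these compounds.

Compound 1 `CN1CCN(CCn2c(N)c(-c3nc4ccccc4[nH]3)c3nc(C#N)c(C#N)nc32)CC1`: > 50000 nM (a limit)
Compound 2 `CN1CCN(CCCn2c(N)c(-c3nc4ccccc4[nH]3)c3nc(C#N)c(C#N)nc32)CC1`: 15600 nM

Within the data shown here, in a functional assay on HeLa cells (Homo sapiens) for antiproliferative activity, read by MTT assay, with a stated time of 48 h (on this read-out higher numbers stand for weaker inhibition and lower numbers for stronger inhibition), compound 2 gives 15600 nM, the only actual number so far. Compound 1 sits at > 50000 nM, which is a limit of the assay.

Compound 3 `CCCCn1c(N)c(-c2nc3ccccc3[nH]2)c2nc(C#N)c(C#N)nc21` differs from compound 2 as follows: methyl in place of 4-methylpiperazin-1-yl on a saturated chain carbon, three bonds along the chain from an aromatic nitrogen. The chain becomes butyl, with methyl in place of 4-methylpiperazin-1-yl on a saturated chain carbon, three bonds along the chain from an aromatic nitrogen.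

Among the measured compounds shown here, the single measured step, an at least 3.2-fold lower number from compound 1 to compound 2 (0.50 log units; beyond the scatter), keeps the 4-methylpiperazin-1-yl group, so it bears only indirectly on its removal. For the measured compounds named here, no measured step shows that removal, and the direction stays open.

The expected step is a 1.0-fold lower number from compound 2 to compound 3 (0.02 log units; within the scatter), with no shift beyond the scatter as the central expectation. In this assay compound 3 is estimated at 15000 nM, with an expected range of 3000 nM to 50000 nM.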

Compound 3, half-maximal inhibitory concentration: > 50000 nM
Compound 3: only a limit was reported; the forecaster's own chance of this, stated with the estimate: 25%; middle value at least 3.3-fold (0.52 log units) from the limit.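

In this assay compound 3 gives > 50000 nM, which is a limit of the assay. Methyl in place of 4-methylpiperazin-1-yl, on a saturated chain carbon three bonds along the chain from an aromatic nitrogen, gives an at least 3.2-fold higher number from compound 2 to compound 3 (0.50 log units; beyond the scatter), so in these compounds the one measured number goes with the 4-methylpiperazin-1-yl group and is not kept by the plain butyl chain on the shared core. The step from compound 1 to compound 3 cannot be read, and the comparison stops at the limit: the limit of > 50000 nM in this assay, at which 2 of the 3 values shown sit.

Still open, on these data alone, is whether another amine in place of 4-methylpiperazin-1-yl, such as morpholin-4-yl or dimethylamino, would keep a measurable number. As far as these compounds go, it is also open whether a longer chain carrying 4-methylpiperazin-1-yl would move the number further from that of compound 2.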